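Notes on the carbonyl substituent and MCF7 cytotoxicity

This account rests on a few compounds, and the source may have more. Where it says the series, first, only, none or still open, it means among the compounds named here.

Values in a functional assay on MCF7 cells (Homo sapiens) for cytotoxicity, read by MTT assay, with a stated time of 48 h (a higher number here means a weaker inhibitor, a lower number a stronger inhibitor), for the measured compounds:

- compound 1 `C=C/C(C)=C\CC/C(C)=C/c1cc(C(=O)O)co1` gives 61900 nM in this assay
- compound 2 `C=C/C(C)=C/CC/C(C)=C/c1cc(C(=O)O)co1` gives 74500 nM in this assay
- compound 3 `C=C/C(C)=C/CC/C(C)=C/c1cc(C(=O)OC)co1` gives 28900 nM in this assay

Compound 1 at 61900 nM sits level with compound 2, and compound 3 has the lowest number of the three. Compound 4 `C=C/C(C)=C\CC/C(C)=C/c1cc(C(=O)Nc2ccc(C)cc2)co1` is still unmeasured. It carries (4-methylphenyl)amino in place of hydroxy on a carbonyl carbon of compound 1, a change counted as (4-methylphenyl)amino in place of hydroxy on a carbonyl carbon in the structures.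

Two measured steps are available. The first, a 1.2-fold higher number from compound 1 to compound 2 (0.08 log units; within the scatter), comes with the fact that compounds 1 and 2 differ only in the configuration as drawn and so offers no guide to a change at the carbonyl carbon. Within the data shown here, the second, a 2.6-fold lower number from compound 2 to compound 3 (0.41 log units; beyond the scatter), is the only step that alters this carbonyl group, and it replaces the acid of compound 2 with the methyl ester of compound 3. On that single modest step, a move to a lower number is expected in this assay, of similar or somewhat larger size. The entering group is far larger than methyl, so the range stays wide. The expected step is a 2.8-fold lower number from compound 1 to compound 4 (0.45 log units; beyond the scatter) as an estimate. For compound 4 the estimated value is 22000 nM, with an expected range from 7000 nM to 60000 nM in this assay.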

Compound 4, half-maximal inhibitory concentration: 65300 nM
Estimate against measurement, compound 4: 3.0-fold (0.47 log units) below; measured number outside the range, above it.
By their numbers in this assay, from the lowest: compound 3; then compounds 1, 4 and 2 (each within the scatter of the next).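

In this assay, (4-methylphenyl)amino in place of hydroxy on the carbonyl carbon gives a 1.1-fold higher number from compound 1 to compound 4 (0.02 log units; within the scatter), so a group of 8 heavy atoms with a six-membered aromatic ring stands level with the hydroxy of the acid. This position therefore does not answer in one direction to every replacement of hydroxy: the methyl ester gives a 2.6-fold lower number from compound 2 to compound 3 (0.41 log units; beyond the scatter), a modest move beyond the scatter, whereas the (4-methylphenyl)amino group gives no readable move at all. The two steps start from different acids, but those acids can serve as a single baseline, as their own step is within the scatter and the only difference between them lies in: the fact that compounds 1 and 2 differ only in the configuration as drawn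

Going by these compounds, what remains open is whether the lower number of compound 3 belongs to esters in general or to the methyl ester alone, and an ethyl ester on the same carbonyl carbon would bear on that. A small amine-derived group such as methylamino would show whether the level result of compound 4 extends to amides generally or is tied to the (4-methylphenyl)amino group.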